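A few compounds are considered here, and "the series" means these few. Any claim that something is new, unique, unknown or untested is made for them only; others in the source may bear on it.

Measured in a functional assay on the whole organism (strain Wistar) for inhibition, with Rattus norvegicus as the target, read by paw edema, with stated times of 60 min and 24 h, at a dose of 100 mg/kg by the oral route; a higher number here means more inhibition at the dose given (going by the name of the read-out), a lower number less inhibition:
compound 1 `COc1cc2c(cc1OC)C(CC(=O)N(C)C)CC2` gives 23.3%
compound 2 `CCCCCCNC(=O)CC1CCc2cc(OC)c(OC)cc21` gives 45.5%
compound 3 `COc1cc2c(cc1OC)C(CC(=O)NCc1ccccc1)CC2` gives 43.3%

Compound 1 stands lowest of the three. The nearest is compound 3, reached by a number 20 percentage points higher from compound 1 to compound 3 (beyond the scatter); the furthest is compound 2, reached by a number 22.2 percentage points higher from compound 1 to compound 2 (beyond the scatter). Between the two larger amides the difference is a number 2.2 percentage points lower from compound 2 to compound 3 (within the scatter), so they are not separable here.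

The step followed is from compound 1 to compound 4 `COc1cc2c(cc1OC)C(CC(=O)N1CCOCC1)CC2`: morpholin-4-yl in place of dimethylamino on a carbonyl carbon. Both measured steps from compound 1 change the same dimethylamino on the carbonyl carbon, and both raise the read-out by a modest, roughly equal amount. Among the compounds with values here, they differ from this step in that each introduces a group carrying an amide hydrogen, whereas morpholin-4-yl, like dimethylamino, leaves the nitrogen fully substituted; no measured pair speaks to that. The expectation for compound 4 is therefore a small rise at most, a number 6.7 percentage points higher from compound 1 to compound 4 (within the scatter), with a real chance of no change beyond the scatter. Compound 4 is estimated at 30% in this assay, within 15% to 47%.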

Compound 4, a percentage reported as inhibition, in the whole organism at one dose (the size of the read-out at that dose, not a potency): 23.3%
The estimate for compound 4 lay 6.7 percentage points above the measured number, within the range that was stated.
By their numbers in this assay, from the lowest: compounds 1 and 4 (each within the scatter of the next); then compounds 3 and 2 (each within the scatter of the next).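

In this assay, morpholin-4-yl on the carbonyl carbon behaves like dimethylamino, with no change at the digits printed from compound 1 to compound 4 (within the scatter), even though it brings more heavy atoms, a six-membered ring and a hydrogen-bond acceptor. Adding heavy atoms at this position therefore does not by itself reproduce the higher numbers: hexylamino and benzylamino stand clear of morpholin-4-yl, with a number 22.2 percentage points lower from compound 2 to compound 4 (beyond the scatter) and a number 20 percentage points lower from compound 3 to compound 4 (beyond the scatter). Across these four compounds, the two amides with a fully substituted nitrogen, compounds 1 and 4, form the lower pair and the two that keep the amide hydrogen, compounds 2 and 3, form the upper pair, with no compound going against this split; no evidence is available on what lies behind it.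

Four compounds cannot separate the amide hydrogen from the particular hexyl or benzyl group, and a hexylamino or benzylamino carrying an added methyl on its nitrogen would test that split directly. Going by these compounds, it also remains open whether the ring oxygen of morpholin-4-yl matters at all, a question that piperidin-1-yl on the same carbonyl carbon would address.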